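This account rests on a few compounds, and the source may have more. Where it says the series, first, only, none or still open, it means among the compounds named here.

Measured so far in an ADME assay, at pH 3; on this read-out higher numbers stand for a longer-lived compound and lower numbers for a shorter-lived compound:
compound 1, `COc1cnc(C[S+]([O-])c2nc3cc(OCC(F)(F)F)ccc3[nH]2)c(C)c1OC`, gives 0.167 h;
compound 2, `COc1ccnc(C[S+]([O-])c2nc3cc(OCC(F)(F)F)ccc3[nH]2)c1C`, gives 0.0833 h;
compound 3, `COc1cnc(C[S+]([O-])c2nc3cc(OC(F)(F)C(F)F)ccc3[nH]2)cc1OC`, gives 0.317 h.

Among the measured compounds shown here, compound 3 and compound 1 lie within the scatter of each other; compound 3 against compound 2 shows a gap beyond it, for which no single step is counted here.

Not yet measured is compound 4, `COc1ccnc(C[S+]([O-])c2nc3cc(OC(F)(F)C(F)F)ccc3[nH]2)c1`. It differs from compound 3 by hydrogen in place of methoxy on an aromatic carbon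

The change from compound 1 to compound 2 is of the same kind: hydrogen in place of methoxy on an aromatic carbon

The surroundings are not identical: in compound 1 the place is also meta to a methyl group, which compound 3 lacks. The difference between the two cores is not broken down here. The measured step of this kind gave a 2.0-fold lower number from compound 1 to compound 2 (0.30 log units; within the scatter).

The step from compound 3 to compound 4 in this assay is expected to be about a 2.0-fold lower number from compound 3 to compound 4 (0.30 log units; within the scatter), resting on compound 1 to compound 2 giving a 2.0-fold lower number from compound 1 to compound 2 (0.30 log units; within the scatter). Compound 4 is thus estimated at 0.16 h, expected between 0.08 h and 0.32 h.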

Compound 4, half-life: 0.167 h
Compound 4: middle estimate off by 1.0-fold (0.02 log units), on the low side, and the stated range covers the measured number.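

In this assay, hydrogen in place of methoxy on an aromatic carbon gives a 1.9-fold lower number from compound 3 to compound 4 (0.28 log units; within the scatter), and this step agrees with the one seen earlier on a different core: the same change on two cores in this assay, a 2.0-fold lower number (0.30 log units; within the scatter) from compound 1 to compound 2 and a 1.9-fold lower number (0.28 log units; within the scatter) from compound 3 to compound 4, 1.1-fold (0.02 log units) apart, within the scatter of two such steps Each step taken alone lies within the scatter, so the agreement supports carrying the size of this change from one core to the other only as a rough guide, and neither step establishes a real difference in half-life by itself. Two pairs on cores that differ in more than one place do not show how far the change would carry to further cores in the series, and they give no reason for the agreement.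

No compound shown carries a group other than hydrogen or methoxy at this place, such as an amine or a longer alkoxy chain. From the compounds shown here alone, the half-life of such a compound remains open. Going by these compounds, whether the two steps would also agree on any other read-out remains open too.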